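Aryl swap on the saturated ring carbon: compound 3

A few compounds are considered here, and "the series" means these few. Any claim that something is new, unique, unknown or untested is made for them only; others in the source may bear on it.

Measured so far in a functional assay on BGC-823 cells (Homo sapiens) for antiproliferative activity, read by MTT assay, tested at 1 uM; on this read-out higher numbers stand for a stronger effect at the one concentration tested and lower numbers for a weaker effect:
compound 1 `COc1cc(C2=NN(C(C)=O)C(c3cc(Cl)cc(Cl)c3)O2)cc(OC)c1OC` gives 0%
compound 2 `COc1cc(C2=NN(C(C)=O)C(c3cccc(OC)c3OC)O2)cc(OC)c1OC` gives 3.8%

Both numbers sit close to the bottom of the scale. For the measured compounds named here, compound 2 holds the higher of the two, yet the only step measured so far, a number 3.8 percentage points higher from compound 1 to compound 2 (within the scatter), does not separate the two compounds, so neither can be called the more active.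

The next compound, compound 3 `COc1cc(C2=NN(C(C)=O)C(c3ccc(F)cc3)O2)cc(OC)c1OC`, is not yet measured. Its change from compound 2 is 4-fluorophenyl in place of 2,3-dimethoxyphenyl on a saturated ring carbon. Going by the values given here, the one step that bears on this change is the earlier exchange of the aryl group on the same saturated ring carbon, a number 3.8 percentage points higher from compound 1 to compound 2 (within the scatter), which stayed within the scatter even though the two aryl groups differ in size and in number of acceptors. Among the compounds with values here, a 4-fluorophenyl group on this carbon has no measured precedent, so the expectation rests on that single step alone.

Compound 3 is therefore expected to show no step beyond the scatter, a number 1.8 percentage points lower from compound 2 to compound 3 (within the scatter), because a number 3.8 percentage points higher from compound 1 to compound 2 (within the scatter) gave none. Compound 3 is estimated at 2%, with a range from -8% to 12%.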

Compound 3, a percentage reported as inhibition, at one concentration (the size of the read-out at that concentration, not a potency): -0.4%
For compound 3 the middle estimate is 2.4 percentage points above the measured one; the range from low to high includes it.
By their numbers in this assay, from the lowest: compounds 3, 1 and 2 (each within the scatter of the next).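

On the saturated ring carbon of the shared core, 4-fluorophenyl now stands as a third aryl group, and in this assay it gives a number 4.2 percentage points lower from compound 2 to compound 3 (within the scatter) and a number 0.4 percentage points lower from compound 1 to compound 3 (within the scatter) on this read-out. The exchange of 2,3-dimethoxyphenyl, with its hydrogen-bond acceptors, for the smaller 4-fluorophenyl, which has none, therefore leaves the number unresolved, as does the exchange of 3,5-dichlorophenyl for 4-fluorophenyl, so all three aryl groups at this position now stand within the scatter of one another, close to the bottom of the scale, with no order among them at the one concentration tested. No independent evidence bears on why these three numbers stay together.

The compounds shown carry only substituted phenyl groups on this carbon, so it remains open whether an aminomethyl group, a carboxylic acid on the phenyl ring or a longer alkyl chain in place of the aryl group would lift the read-out clear of the scatter. Going by these compounds, the acetyl group on the ring nitrogen and the trimethoxyphenyl group stay the same throughout, so what a longer acyl chain or a free amine at those places would do also remains open.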